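Ethoxy for chloro on the pendant aryl of compound 2

The source may report more compounds than this note shows. Statements on the series, on what has been measured and on what is new or still open speak of the compounds shown alone.

Measured so far:
Compound 1 `COc1cc(C(=O)c2sc3ccccc3c2-c2ccc(F)cc2)cc(OC)c1OC` gives 2100 nM in a functional assay on K562 cells (Homo sapiens) for antiproliferative activity, read by MTT assay, with a stated time of 72 h; on this read-out lower numbers stand for stronger inhibition and higher numbers for weaker inhibition.
Compound 2 `COc1cc(C(=O)c2sc3ccccc3c2-c2ccc(Cl)cc2)cc(OC)c1OC` gives 4200 nM in this assay.
Compound 3 `COc1ccc(OC)c(-c2c(C(=O)c3cc(OC)c(OC)c(OC)c3)sc3ccccc23)c1` gives > 10000 nM in this assay, a limit of the assay and not a number.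

Compound 2 holds the highest of the two numbers, and compound 1 is its nearest neighbour, the step of a 2.0-fold higher number from compound 1 to compound 2 (0.30 log units; within the scatter) lying within the scatter. Exchanging the 4-chlorophenyl for 2,5-dimethoxyphenyl gives an at least 2.3-fold higher number from compound 2 to compound 3 (0.37 log units; beyond the scatter), and from the fluoro analogue an at least 4.7-fold higher number from compound 1 to compound 3 (0.67 log units; beyond the scatter), both read against (the limit of > 10000 nM in this assay, at which 1 of the 3 values shown sits).

Compound 4 `CCOc1ccc(-c2c(C(=O)c3cc(OC)c(OC)c(OC)c3)sc3ccccc23)cc1` differs from compound 2 by ethoxy in place of chloro on an aromatic carbon. Within the data shown here, of the measured steps, the halogen swap from compound 1 to compound 2 stays within the scatter, while the only step that introduces alkoxy groups on this aryl, from compound 2 to compound 3, is at least modest toward weaker inhibition. A single ethoxy at the same place as the chloro is a smaller change than that; a modest rise in the number is therefore expected, a 1.7-fold higher number from compound 2 to compound 4 (0.22 log units; within the scatter). Compound 4 is expected to give 7000 nM in this assay, with a range from 2500 nM to 20000 nM.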

Compound 4, half-maximal inhibitory concentration: 3100 nM
Beside the measured number, compound 4's estimate is 2.3-fold (0.35 log units) above it, within the range that was stated.
By their numbers in this assay, from the lowest: compounds 1, 4 and 2 (each within the scatter of the next). At a limit, above all of these: compound 3.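

In this assay, the para position accepts an alkoxy group as readily as a halogen: ethoxy in place of chloro gives a 1.4-fold lower number from compound 2 to compound 4 (0.13 log units; within the scatter), and ethoxy in place of fluoro gives a 1.5-fold higher number from compound 1 to compound 4 (0.17 log units; within the scatter). Fluoro, chloro and ethoxy therefore cannot be told apart at this place. The weak result of the 2,5-dimethoxyphenyl analogue does not follow from an alkoxy group as such, with an at least 3.2-fold lower number from compound 3 to compound 4 (0.50 log units; beyond the scatter), a step read against a limit of the assay and not against a number: the limit of > 10000 nM in this assay, at which 1 of the 4 values shown sits.

As far as these compounds go, whether an amine, a carboxylic acid or a longer chain such as butoxy at this place would move the number beyond the scatter remains open. Also open, from the compounds shown here alone, is which of the two methoxy groups of compound 3 carries its difference from compound 4.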